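The compounds below may be only part of what the source reports. "The series", "measured", "known", "first", "only" and "open" are said of these compounds alone.

Of the compounds shown here, three from a series of pyrazole-bearing ureas have been measured for growth inhibition of kidney-cancer cells. Compound 1 `COc1cc(-c2nn(-c3cccc(NC(=O)Nc4cc(C(F)(F)F)cc(C(F)(F)F)c4)c3)cc2-c2ccncc2)ccc1Cl` gives 612 nM in a functional assay on A498 cells (Homo sapiens) for inhibition, read by sulforhodamine B assay, with a stated time of 48 h; a lower number here means a stronger inhibitor of growth, a higher number a weaker inhibitor of growth. Compound 2 `COc1cc(-c2nn(-c3cccc(NC(=O)Nc4ccc(Cl)c(Cl)c4)c3)cc2-c2ccncc2)ccc1Cl` gives 1140 nM in the same assay, and compound 3 `O=C(Nc1cccc(-n2cc(-c3ccncc3)c(-c3ccc(Cl)c(O)c3)n2)c1)Nc1ccc(Cl)c(Cl)c1` gives 940 nM. Compound 2 thus holds the highest number of the three, but both neighbours sit within the scatter of it: compound 3 is only a 1.2-fold lower number from compound 2 to compound 3 (0.08 log units; within the scatter) away, and compound 1 differs from it no more than repeated measurements would. Among the measured compounds shown here, the one single-point step that has been measured, from compound 2 to compound 3, is therefore a change that did not move the assay beyond its noise.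

Compound 4 `COc1cc(-c2nn(-c3cccc(NC(=O)c4ccccc4)c3)cc2-c2ccncc2)ccc1Cl` is made from compound 2 by a change at a different spot: phenyl in place of (3,4-dichlorophenyl)amino on a carbonyl carbon. The urea of compound 2 becomes a simple benzamide. For the measured compounds named here, no measured step touches this part of the molecule, so nothing in the present data tells how far the number might move. With the other three compounds all falling within a narrow band, the expectation for compound 4 is built on that band alone, widened generously. Compound 4 is estimated to give 2500 nM, with a plausible range from 700 nM to 9000 nM, which would correspond to an expected step of a 2.2-fold higher number from compound 2 to compound 4 (0.34 log units; beyond the scatter).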

Compound 4, concentration for 50% growth inhibition: 361 nM
Compound 4: middle estimate off by 6.9-fold (0.84 log units), on the high side; measured number outside the range, below it.
By their numbers in this assay, from the lowest: compounds 4, 1, 3 and 2 (each within the scatter of the next, the first and the last beyond it).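

In this assay, the change on the carbonyl carbon gives a 3.2-fold lower number from compound 2 to compound 4 (0.50 log units; beyond the scatter), which lies beyond the scatter, unlike the change at the oxygen on the aromatic ring, a 1.2-fold lower number from compound 2 to compound 3 (0.08 log units; within the scatter). This shows that the number responds to what sits on this carbonyl carbon, and that the full urea with its (3,4-dichlorophenyl)amino group is not required for growth inhibition in these cells, as the simpler benzamide of compound 4 gives the lower number. No measurement shown here explains why the number falls with this change.

The change removes the amino nitrogen, with its hydrogen-bond donor, and the chlorine atoms in a single step, so the compounds shown cannot assign the drop to either loss. A plain phenylamino group on the carbonyl carbon would keep the nitrogen without the chlorine atoms, a 3,4-dichlorophenyl group would keep the chlorine atoms without the nitrogen, and a non-aromatic group such as a cyclohexyl ring would test whether an aromatic ring is needed there at all.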